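The source may report more compounds than this note shows. Statements on the series, on what has been measured and on what is new or still open speak of the compounds shown alone.

In a functional assay on MDA-MB-231 cells (Homo sapiens) for antiproliferative activity, read by MTT assay, with a stated time of 24 h (a lower number here means a stronger inhibitor, a higher number a weaker inhibitor), compound 2 (`CCCCc1oc2ccccc2c1C(=O)c1ccc(OCCCC(=O)N2CCOCC2)cc1`) gives 31600 nM. Compound 1 (`CCCCc1oc2ccccc2c1C(=O)c1ccc(OCCCC(=O)N2CCCCC2)cc1`) gives 36000 nM, and the two values lie within the usual scatter of each other, so they cannot be ranked. Compound 3 (`CCCCc1oc2ccccc2c1C(=O)c1ccc(OCCCC(=O)NCc2ccccc2)cc1`) has benzylamino in place of morpholin-4-yl on a carbonyl carbon. Among the compounds with values here, the only measured step at this carbonyl carbon is a 1.1-fold lower number from compound 1 to compound 2 (0.06 log units; within the scatter), with morpholin-4-yl in place of piperidin-1-yl. Within the data shown here, no measured compound carries benzylamino, so this single step is only a weak guide, and the range must stay wide. Still, it offers no sign of a large shift, so no change beyond the scatter is expected in this assay, and the expected step is a 1.1-fold lower number from compound 2 to compound 3 (0.05 log units; within the scatter). For compound 3 the estimated value is 28000 nM, with an expected range from 12000 nM to 65000 nM.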

Compound 3, half-maximal inhibitory concentration: > 50000 nM
Compound 3: only a limit was reported (the forecaster's own chance of this, stated with the estimate: 10%); at least 1.7-fold (0.25 log units) between middle value and limit.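

In this assay compound 3 gives only a limit, not a number: the limit of > 50000 nM in this assay, at which 1 of the 3 values shown sits.

Replacing either ring group on the carbonyl carbon with benzylamino gives an at least 1.5-fold higher number from compound 2 to compound 3 (0.19 log units; that floor lies within the scatter) and an at least 1.3-fold higher number from compound 1 to compound 3 (0.14 log units; that floor lies within the scatter). Within the data shown here, compounds 1 and 2 compared only two six-membered non-aromatic rings, whereas compound 3 shows that a group with an aromatic ring and an amide hydrogen at this carbonyl carbon brings no lower number, although the true size of the rise remains unknown.

The compounds shown leave open how far the value of compound 3 lies past the limit, so the size of this step stays unsettled. They also leave open whether a different group on this carbonyl carbon, such as dimethylamino or a piperazine, could lower the number in this assay.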